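The source may report more compounds than this note shows. Statements on the series, on what has been measured and on what is new or still open speak of the compounds shown alone.

Working notes on the series.

Three analogues sharing one core have been measured in a functional assay on MKN-45 cells (Homo sapiens) for cytotoxicity, read by MTT assay, with a stated time of 72 h; on this read-out higher numbers stand for weaker inhibition and lower numbers for stronger inhibition. Compound 1 `COc1cc2c(Oc3ccc(NC(=S)N/N=C/c4ccccc4)cc3F)ccnc2cc1OCCCN1CCCCC1` carries a phenyl on the carbon double-bonded to nitrogen; in this assay compound 1 gives 710 nM. Compound 2 `COc1cc2c(Oc3ccc(NC(=S)N/N=C/c4ccc(F)c(F)c4)cc3F)ccnc2cc1OCCCN1CCCCC1` gives 740 nM, and compound 3 `COc1cc2c(Oc3ccc(NC(=S)N/N=C/c4ccc(Cl)cc4)cc3F)ccnc2cc1OCCCN1CCCCC1` gives 500 nM. Compound 3 holds the lowest of the three numbers, but each neighbour lies within the scatter: a 1.4-fold lower number from compound 1 to compound 3 (0.15 log units; within the scatter) and a 1.5-fold lower number from compound 2 to compound 3 (0.17 log units; within the scatter), while a 1.0-fold higher number from compound 1 to compound 2 (0.02 log units; within the scatter).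

Compound 4 `COc1cc2c(Oc3ccc(NC(=S)N/N=C/c4ccc(F)cc4Cl)cc3F)ccnc2cc1OCCCN1CCCCC1` is the next member, not yet measured. The change from compound 3 is 2-chloro-4-fluorophenyl in place of 4-chlorophenyl on a carbon with a double bond to nitrogen. All three steps measured so far swap one substituted or unsubstituted phenyl for another at this same carbon, and none moved the number beyond the scatter. On that basis no step beyond the scatter is expected in this assay for the change to compound 4, with the estimated step being a 1.1-fold higher number from compound 3 to compound 4 (0.04 log units; within the scatter). The value of compound 4 in this assay is therefore expected to be about 550 nM, within a range from 280 nM to 1100 nM.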

Compound 4, half-maximal inhibitory concentration: 820 nM
Compound 4: the middle estimate sits 1.5-fold (0.17 log units) below what was measured, within the range that was stated.
By their numbers in this assay, from the lowest: compounds 3, 1, 2 and 4 (each within the scatter of the next).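

The 2-chloro-4-fluorophenyl group extends what has been seen at this carbon with a double bond to nitrogen, and in this assay its three new steps give a 1.6-fold higher number from compound 3 to compound 4 (0.21 log units; within the scatter) and a 1.1-fold higher number from compound 2 to compound 4 (0.04 log units; within the scatter) and also a 1.2-fold higher number from compound 1 to compound 4 (0.06 log units; within the scatter) without any of them leaving the scatter. The earlier compounds shown here carried only phenyl, 3,4-difluorophenyl and 4-chlorophenyl here, so a 2-chloro group and a mix of chloro and fluoro on this phenyl are new. Across all four compounds, no listed step at this carbon separates any two of them beyond the scatter.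

From the compounds shown here alone, whether a methoxy, a nitrile or a carboxylic acid on this phenyl, or a cyclohexyl in place of it, would give a step beyond the scatter remains open. No measurement at hand offers an explanation for the values at this position.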